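Triazole-linked furanone analogues against pancreatic cancer cells

The source may report more compounds than this note shows. Statements on the series, on what has been measured and on what is new or still open speak of the compounds shown alone.

The measured compounds are compound 1 `O=C1O[C@H]([C@@H](O)Cn2cc(-c3cc(C(F)(F)F)cc(C(F)(F)F)c3)nn2)C(OCc2ccccc2)=C1OCc1ccccc1` with 66500 nM, compound 2 `O=C1O[C@H]([C@@H](O)Cn2cc(CNS(=O)(=O)c3ccc(F)cc3)nn2)C(OCc2ccccc2)=C1OCc1ccccc1` with 34700 nM, and compound 3 `COc1ccccc1-c1cn(C/C=C2\OC(=O)C(OCc3ccccc3)=C2OCc2ccccc2)nn1`, whose result is a limit of the assay, > 100000 nM.

All three were tested in a functional assay on CFPAC-1 cells (Homo sapiens) for antiproliferative activity, read by MTT assay, with a stated time of 72 h; on this read-out lower numbers stand for stronger inhibition and higher numbers for weaker inhibition. Compound 2 holds the lowest of the two numbers reported; the nearest is compound 1, and the gap between the two falls within the usual scatter of this assay, so no order can be read from them. For compound 3 only a limit is available (the limit of > 100000 nM in this assay, at which 1 of the 3 values shown sits).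

The unmeasured compound 4 `O=C1O[C@H]([C@@H](O)Cn2cc(-c3cc(F)cc(F)c3)nn2)C(OCc2ccccc2)=C1OCc1ccccc1` shares the core of compound 2 and differs from it in one place: 3,5-difluorophenyl in place of (((4-fluorophenyl)sulfonyl)amino)methyl on an aromatic carbon. Going by the values given here, no step between two measured compounds matches this change, so its size can only be guessed from what compound 1 shows with its own substituted phenyl on the same ring carbon, 66500 nM.

Compound 4 is therefore expected to sit close to compounds 1 and 2, with a step from compound 2 of a 1.6-fold higher number from compound 2 to compound 4 (0.20 log units; within the scatter), which would not exceed the scatter. The estimated value for compound 4 is 55000 nM, with a range from 25000 nM to 120000 nM.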

Compound 4, half-maximal inhibitory concentration: 62400 nM
Compound 4: the middle estimate sits 1.1-fold (0.05 log units) below what was measured; the measured number falls inside the stated range.
By their numbers in this assay, from the lowest: compounds 2, 4 and 1 (each within the scatter of the next). At a limit, above all of these: compound 3.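

In this assay the position on the aromatic carbon of the five-membered aromatic ring with 3 nitrogen now has its first step between two measured compounds that differ in one place (a 1.8-fold higher number from compound 2 to compound 4 (0.25 log units; within the scatter)). The exchange is a large one in structure: the (((4-fluorophenyl)sulfonyl)amino)methyl group that leaves has 12 heavy atoms, 1 hydrogen-bond donor and 2 hydrogen-bond acceptors, the 3,5-difluorophenyl group that enters has 8 heavy atoms and 0 of either, and both carry one six-membered aromatic ring of carbon only, yet the two numbers cannot be told apart. Nothing measured here offers a reason for this result.

On these data alone, whether an amine or a carboxylic acid on this ring carbon would give a step beyond the scatter remains open, as does the effect of a longer chain between this carbon and the aromatic ring. The step also rests on this assay alone, so whether the same holds on another cell line stays unanswered.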